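Aromatic chloro to trifluoromethyl in the imidazoline series

The source may report more compounds than this note shows. Statements on the series, on what has been measured and on what is new or still open speak of the compounds shown alone.

Measured compounds:
compound 1 `CSc1ccc(C)cc1NCC1=NCCN1` gives 0.11 nM
compound 2 `CS(=O)(=O)c1ccc(C(F)(F)F)cc1NCC1=NCCN1` gives 1100 nM
compound 3 `CSc1ccc(Cl)cc1NCC1=NCCN1` gives 0.437 nM

In a functional assay for agonist activity at Alpha-1A adrenergic receptor (Homo sapiens) (on this read-out lower numbers stand for an effect already at smaller amounts and higher numbers for an effect only at larger amounts of compound), compound 3 stands second highest of the three numbers. Among the measured compounds shown here, its nearest neighbour is compound 1, and the only single-point step in the set runs between them: a 4.0-fold higher number from compound 1 to compound 3 (0.60 log units; beyond the scatter). For the measured compounds named here, the furthest value belongs to compound 2, which differs from compound 3 in two places at once, so its number is noted but no step is drawn from it.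

Compound 4 `CSc1ccc(C(F)(F)F)cc1NCC1=NCCN1` is not yet measured in this assay. It differs from compound 3 as follows: trifluoromethyl in place of chloro on an aromatic carbon. Going by the values given here, only the step from compound 1 to compound 3 bears on this change, and it shows that swapping the group on this aromatic carbon moves the number by a modest amount. Among the compounds with values here, a further swap of the same kind is therefore expected to give a shift of similar size rather than a large one, and the direction is taken to be upward, since compound 2, the only compound carrying trifluoromethyl, gives 1100 nM.

For compound 4 the expected value is 1.5 nM, within 0.3 nM to 8 nM. The step that this estimate implies is a 3.4-fold higher number from compound 3 to compound 4 (0.54 log units; beyond the scatter).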

Compound 4, half-maximal effective concentration: 10.5 nM
Estimate against measurement, compound 4: 7.0-fold (0.85 log units) below, and the stated range ends below it.
By their numbers in this assay, from the lowest: compound 1; then compound 3; then compound 4; then compound 2.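

In this assay, the aromatic carbon para to the methylsulfanyl group proves far less forgiving than the earlier swap of methyl for chloro suggested: trifluoromethyl in place of chloro gives a 24-fold higher number from compound 3 to compound 4 (1.38 log units; beyond the scatter), a large step where the earlier one was modest. Trifluoromethyl in place of methyl gives a 95-fold higher number from compound 1 to compound 4 (1.98 log units; beyond the scatter), so among the three compounds that carry methylsulfanyl, the numbers rise from methyl through chloro to trifluoromethyl, and none of the three goes against that order. With trifluoromethyl held constant, methylsulfanyl in place of methylsulfonyl gives a 100-fold lower number from compound 2 to compound 4 (2.02 log units; beyond the scatter), so the sulfur-bearing group carries a large step of its own.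

Still open, from the compounds shown here alone, is how other groups on this carbon, such as methoxy, nitrile or a plain hydrogen, would fall relative to these three, and whether methylsulfonyl costs as much alongside methyl or chloro as it does alongside trifluoromethyl. The data shown offer no measurement that would explain the size of these steps.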